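Replacing 5-cyanopentyl with phenyl on the shared core

A few compounds are considered here, and "the series" means these few. Any claim that something is new, unique, unknown or untested is made for them only; others in the source may bear on it.

Of the compounds shown here, two have numbers so far. In a physicochemical assay for solubility, in phosphate buffer, with a stated time of 18 h (on this read-out higher numbers stand for higher solubility and lower numbers for lower solubility), compound 1 (`N#Cc1c(N)nc2nc(C3CCCC3)ncc2c1N`) gives 89000 nM as its reading. Compound 2 (`CC(C)(C)c1nc(CCCCCC#N)c2c(N)c(C#N)c(N)nc2n1`) gives 6000 nM and so holds the lower of the two numbers, a gap beyond the usual scatter of repeat measurements. Compound 3 (`CC(C)(C)c1nc(-c2ccccc2)c2c(N)c(C#N)c(N)nc2n1`) has no reading yet. The change from compound 2 (phenyl in place of 5-cyanopentyl on an aromatic carbon) puts phenyl in place of 5-cyanopentyl on an aromatic carbon next to the ring nitrogen. Among the measured compounds shown here, no measured pair shows this exchange, so what follows is a judgement and not a trend taken from the data. In this assay the expected change is a 3.0-fold lower number from compound 2 to compound 3 (0.48 log units; beyond the scatter) in the downward direction, a step that should just clear the scatter. For compound 3 the estimated reading is 2000 nM with a likely range from 400 nM to 8000 nM when it is measured.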

Compound 3, solubility: 4000 nM
For compound 3 the middle estimate is 2.0-fold (0.30 log units) below the measured one; the measured number falls inside the stated range.
By their numbers in this assay, from the lowest: compounds 3 and 2 (each within the scatter of the next); then compound 1.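

In this assay, putting phenyl in place of 5-cyanopentyl on this aromatic carbon gives a 1.5-fold lower number from compound 2 to compound 3 (0.18 log units; within the scatter), so the read-out does not separate the two compounds. This is the only pair shown that differs in one place, and it sets a chain with no ring, ending in a nitrile, against an aromatic ring of carbon only, yet the two numbers stay within the scatter of each other. No measurement at hand offers an explanation for this match.

Going by these compounds, whether a different kind of group on this same carbon, such as an amine or a carboxylic acid, would give a step beyond the scatter remains open. Also open, on these data alone, is whether a shorter chain or a saturated ring such as cyclohexyl would read like these two groups.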